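The source may report more compounds than this note shows. Statements on the series, on what has been measured and on what is new or still open speak of the compounds shown alone.

Compound 1 `COc1cc(-c2nnc(SCc3ccccc3)n2-c2ccc(N(C)C)cc2)cc(OC)c1OC` is the parent of the shared core. In a functional assay on HT-29 cells (Homo sapiens) for inhibition, read by MTT assay, with a stated time of 48 h (on this read-out higher numbers stand for weaker inhibition and lower numbers for stronger inhibition), compound 1 gives only a limit, > 60000 nM. Compound 2 `COc1ccc(C(=O)CSc2nnc(-c3cc(OC)c(OC)c(OC)c3)n2-c2ccc(N(C)C)cc2)cc1` carries (4-methoxyphenyl)carbonyl in place of phenyl on a saturated chain carbon bound to a sulfur; in this assay compound 2 gives 64000 nM. The step that the limit leaves unreadable from compound 1 to compound 2 cannot be sized because one end sits at the limit of > 60000 nM in this assay, at which 1 of the 2 values shown sits. Compound 2 thus stands as the only number shown; the one further value is a limit. Compound 3 `CCOC(=O)CSc1nnc(-c2cc(OC)c(OC)c(OC)c2)n1-c1ccc(N(C)C)cc1` differs from compound 2 by ethoxy in place of 4-methoxyphenyl on a carbonyl carbon. No measured step touches the carbonyl carbon, so nothing shown bears on this change; the single step known, from the parent, is unreadable. For compound 3 in this assay a step of no change at the digits printed from compound 2 to compound 3 (within the scatter) of no size beyond the scatter is expected. Compound 3 is therefore estimated at 64000 nM, between 20000 nM and 200000 nM, with a real chance that only a limit is returned.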

Compound 3, half-maximal inhibitory concentration: 28800 nM
Estimate against measurement, compound 3: 2.2-fold (0.35 log units) above; measured number inside the range.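

Ethoxy in place of 4-methoxyphenyl on a carbonyl carbon gives a 2.2-fold lower number from compound 2 to compound 3 (0.35 log units; beyond the scatter) in this assay, the first readable step in the series, so the group on this carbonyl carbon does change the read-out. In this one pair, a six-membered aromatic ring on the carbonyl carbon is not needed for the lower number. Ethoxycarbonyl in place of phenyl on a saturated chain carbon bound to a sulfur gives an at least 2.0-fold lower number from compound 1 to compound 3 (0.31 log units; beyond the scatter), and this step is a bound and not a size: the limit of > 60000 nM in this assay, at which 1 of the 3 values shown sits.

A single pair cannot separate the effect of removing 4-methoxyphenyl from that of adding ethoxy. The compounds shown also leave open how a carboxylic acid, an amine-derived amide or a longer chain such as butoxy on the carbonyl carbon would read in this assay.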